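Dihydroxyphenyl Analogue of a Quinazoline Semicarbazone

A few compounds are considered here, and "the series" means these few. Any claim that something is new, unique, unknown or untested is made for them only; others in the source may bear on it.

Compound 2 `COc1cc2ncnc(Nc3ccc(F)c(Cl)c3)c2cc1NC(=O)N/N=C/c1ccc(F)cc1` gives 36500 nM in a functional assay on PC-3 cells (Homo sapiens) for cytotoxicity, read by MTT assay, with a stated time of 72 h (on this read-out lower numbers stand for stronger inhibition and higher numbers for weaker inhibition), the higher of the two measured numbers. Its nearest neighbour, compound 1 `O=C(N/N=C/c1cc(Br)c(O)c(Br)c1)Nc1cc2c(Nc3ccc(F)c(Cl)c3)ncnc2cc1O[C@H]1CCOC1`, gives 6160 nM in this assay, a lower number that lies beyond the usual scatter. Compound 3 `COc1cc2ncnc(Nc3ccc(F)c(Cl)c3)c2cc1NC(=O)N/N=C/c1ccc(O)cc1O` differs from compound 2 in one place: 2,4-dihydroxyphenyl in place of 4-fluorophenyl on a carbon with a double bond to nitrogen. Among the measured compounds shown here, no measured pair shows this change, so the expected step is tentative; a modest move toward a lower number is expected, a 2.4-fold lower number from compound 2 to compound 3 (0.39 log units; beyond the scatter), and may not exceed the scatter. Compound 3 is therefore estimated at 15000 nM, with a range from 5000 nM to 45000 nM.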

Compound 3, half-maximal inhibitory concentration: 29500 nM
Estimate against measurement, compound 3: 2.0-fold (0.29 log units) below; the range from low to high includes it.
By their numbers in this assay, from the lowest: compound 1; then compounds 3 and 2 (each within the scatter of the next).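

Putting 2,4-dihydroxyphenyl in place of 4-fluorophenyl on a carbon with a double bond to nitrogen gives a 1.2-fold lower number from compound 2 to compound 3 (0.09 log units; within the scatter) in this assay. At this position, then, adding hydrogen-bond donors and acceptors that 4-fluorophenyl lacks does not separate compound 3 from compound 2 on this read-out. No supporting data bear on this result.

As far as these compounds go, whether an aminophenyl or carboxyphenyl group at this position would move the number beyond the scatter stays open. So does what sets compound 1 apart, since it differs from both in more than one place.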